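The source may hold more compounds than are shown below. What is called first, only, known or untested is meant among the compounds shown, and "the series" means these compounds.

Compounds 1, 2 and 3 share one core and differ in the chains attached to that core and in the substituted benzyl group they carry. Compound 1 `CC(C)Cn1c(=O)c2nc(-c3cnn(Cc4cccc(C(F)(F)F)c4)c3)[nH]c2n(CC(C)C)c1=O` bears a trifluoromethyl on its benzyl ring, and in an assay on CHO cells for displacement of a labelled ligand from adenosine receptor A1 (Homo sapiens) (a higher number here means a weaker inhibitor, a lower number a stronger inhibitor), compound 1 gives 3100 nM. Within the data shown here, compound 2 `CCCn1c(=O)c2nc(-c3cnn(Cc4ccccc4C(F)(F)F)c3)[nH]c2n(CCC)c1=O` carries its trifluoromethyl at another spot on the benzyl ring, and in this assay compound 2 gives 44 nM, the lowest of the two numbers known here, with compound 1 standing far above it, well beyond the scatter. For compound 3 `CCCn1c(=O)c2nc(-c3cnn(Cc4cc(C(F)(F)F)cc(Cl)c4F)c3)[nH]c2n(CCC)c1=O` this assay reports "not determined" (no result reported), so no number is known for it. Compound 4 `CCCn1c(=O)c2nc(-c3cnn(Cc4ccccc4OC)c3)[nH]c2n(CCC)c1=O` is compound 2 with one change: methoxy in place of trifluoromethyl on an aromatic carbon. Among the measured compounds shown here, no measured pair isolates this change, so its size cannot be read from the data; a moderate step is expected, more likely toward a higher number than a lower one, as a 2.7-fold higher number from compound 2 to compound 4 (0.44 log units; beyond the scatter). In this assay compound 4 is therefore estimated at 120 nM, with a likely range from 30 nM to 500 nM.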

Compound 4, inhibition constant: 59 nM
Compound 4: the middle estimate sits 2.0-fold (0.31 log units) above what was measured; the measured number falls inside the stated range.
By their numbers in this assay, from the lowest: compounds 2 and 4 (each within the scatter of the next); then compound 1.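

In this assay methoxy in place of trifluoromethyl on this aromatic carbon gives a 1.3-fold higher number from compound 2 to compound 4 (0.13 log units; within the scatter) and so leaves no change that can be told from scatter. Among these compounds, this is the first pair here that differs in one place only, and it shows that this position tolerates a swap from a group of four heavy atoms with no hydrogen-bond acceptor to one of two heavy atoms with one. Nothing measured here offers an explanation for this result.

As far as these compounds go, whether an amine or a carboxylic acid on this carbon would also leave the number in place remains open. Also open, from the compounds shown here alone, is whether methoxy would give the same result on another carbon of the benzyl ring, or alongside a longer chain on the shared core.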